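Ester chain length and cytotoxicity on A549 cells

A few compounds are considered here, and "the series" means these few. Any claim that something is new, unique, unknown or untested is made for them only; others in the source may bear on it.

Measured compounds:
compound 1, `CCCOC(=O)CCC(=O)N1CCN(CCCOc2cc3c(Nc4ccc(F)c(Cl)c4)ncnc3cc2OC)CC1`: 95.1%
compound 2, `CCCCCOC(=O)CCC(=O)N1CCN(CCCOc2cc3c(Nc4ccc(F)c(Cl)c4)ncnc3cc2OC)CC1`: 87.1%
compound 3, `CCCCCCCCCCOC(=O)CCC(=O)N1CCN(CCCOc2cc3c(Nc4ccc(F)c(Cl)c4)ncnc3cc2OC)CC1`: 95.7%

All three share one core and differ only in the length of the alkyl chain on the ester oxygen. In a functional assay on A549 cells (Homo sapiens) for cytotoxicity, read by MTT assay, with a stated time of 24 h, tested at 10 uM (on this read-out lower numbers stand for a stronger effect and higher numbers for a weaker effect at the one concentration tested), compound 3 gives the top number of the three, but only inside the scatter: the nearest is compound 1, with a number 0.6 percentage points higher from compound 1 to compound 3 (within the scatter), and the furthest is compound 2, with a number 8.6 percentage points higher from compound 2 to compound 3 (within the scatter). The third measured step, a number 8 percentage points lower from compound 1 to compound 2 (within the scatter), is likewise within the scatter. Taken together, lengthening the ester chain from propyl through pentyl to decyl leaves the read-out flat.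

Compound 4, `CCCCCCCCCCCCOC(=O)CCC(=O)N1CCN(CCCOc2cc3c(Nc4ccc(F)c(Cl)c4)ncnc3cc2OC)CC1`, is the next member of the same run. It differs from compound 3 by ethyl in place of hydrogen on a saturated chain carbon, ten or more bonds along the chain from an oxygen next to a carbonyl group. Every measured step bears on this change, since each is a lengthening of the same chain, and none of them moved the number beyond the scatter. The expectation for the step from compound 3 to compound 4 is therefore none beyond the scatter, a number 1.7 percentage points lower from compound 3 to compound 4 (within the scatter). Compound 4 is estimated at 94%, with a range of 83% to 104%.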

Compound 4, a percentage reported as activity, at one concentration (the size of the read-out at that concentration, not a potency): 95.5%
Compound 4: the middle estimate sits 1.5 percentage points below what was measured, within the range that was stated.
By their numbers in this assay, from the lowest: compounds 2, 1, 4 and 3 (each within the scatter of the next).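

Adding ethyl in place of hydrogen on a saturated chain carbon, ten or more bonds along the chain from an oxygen next to a carbonyl group, takes the series to the dodecyl ester and gives in this assay a number 0.2 percentage points lower from compound 3 to compound 4 (within the scatter), so the flat run now holds at this far end of the chain, and the wider comparisons agree, with a number 0.4 percentage points higher from compound 1 to compound 4 (within the scatter) and a number 8.4 percentage points higher from compound 2 to compound 4 (within the scatter). The ethyl change can now be read at two places on the chain, and the two steps agree within their scatter: the same change on two cores in this assay, a number 8 percentage points lower (within the scatter) from compound 1 to compound 2 and a number 0.2 percentage points lower (within the scatter) from compound 3 to compound 4, 7.8 percentage points apart, within the scatter of two such steps. The heptyl change can likewise be read twice, with the same outcome: the same change on two cores in this assay, a number 0.6 percentage points higher (within the scatter) from compound 1 to compound 3 and a number 8.4 percentage points higher (within the scatter) from compound 2 to compound 4, 7.8 percentage points apart, within the scatter of two such steps.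

The compounds shown are all unbranched alkyl esters, and whether a free carboxylic acid, an amide in place of the ester, or a chain ending in an amine would move the number beyond the scatter stays open. A read-out at a single concentration also gives no potency for any of the four compounds.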